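A few compounds are considered here, and "the series" means these few. Any claim that something is new, unique, unknown or untested is made for them only; others in the source may bear on it.

The three measured compounds share one core and differ only in the side chain that carries the acid. Compound 1 `Cc1cc([C@@H]2C[C@H]2C(=O)O)ccc1-c1noc(-c2ccc(OC(C)C)c(C(F)(F)F)c2)n1` bears a 2-carboxycyclopropyl group; in an in vivo ADME assay on the whole organism (strain Sprague-Dawley) for pharmacokinetics, with Rattus norvegicus as the target (on this read-out higher numbers stand for wider distribution into tissues and lower numbers for narrower distribution), compound 1 gives 1.1 L/kg. Compound 2 `Cc1cc(CC(C)C(=O)O)ccc1-c1noc(-c2ccc(OC(C)C)c(C(F)(F)F)c2)n1` carries a 2-carboxypropyl chain instead, and in this assay compound 2 gives 1.5 L/kg. Compound 3 `Cc1cc(CCC(=O)O)ccc1-c1noc(-c2ccc(OC(C)C)c(C(F)(F)F)c2)n1` has a 2-carboxyethyl chain; in this assay compound 3 gives 1.1 L/kg. Compound 3 thus stands level with compound 1 at the digits shown, the two together the lowest of the three numbers, while compound 2 is its furthest neighbour: a 1.4-fold lower number from compound 2 to compound 3 (0.13 log units; within the scatter). The remaining steps are also small, a 1.4-fold higher number from compound 1 to compound 2 (0.13 log units; within the scatter) and no change at the digits printed from compound 1 to compound 3 (within the scatter), so the whole set sits within the usual scatter of this read-out.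

Compound 4 `Cc1cc(C(C)CC(=O)O)ccc1-c1noc(-c2ccc(OC(C)C)c(C(F)(F)F)c2)n1` has not yet been measured. Its difference from compound 3 is methyl in place of hydrogen on a saturated chain carbon bound to an aromatic carbon and a saturated chain carbon. Going by the values given here, the nearest precedent is the step from compound 2 to compound 3, which also concerns a methyl on a saturated chain carbon, though on a different one, and that step stayed within the scatter. On that basis the step of a 1.2-fold higher number from compound 3 to compound 4 (0.07 log units; within the scatter) is expected to stay within the scatter as well. Compound 4 is therefore estimated at 1.3 L/kg, with a likely range from 0.8 L/kg to 2.1 L/kg.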

Compound 4, volume of distribution at steady state: 0.6 L/kg
Compound 4: the middle estimate sits 2.2-fold (0.34 log units) above what was measured, and the stated range ends above it.
By their numbers in this assay, from the lowest: compounds 4, 1, 3 and 2 (each within the scatter of the next, the first and the last beyond it).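

Going by these compounds alone, the methyl's place on the chain turns out to matter in this assay: changing 2-carboxypropyl to 1-(carboxymethyl)ethyl gives a 2.5-fold lower number from compound 2 to compound 4 (0.40 log units; beyond the scatter) and takes the pair beyond the scatter, though only modestly, whereas the earlier steps all stayed within it. The other two steps stay within the scatter: adding the methyl to the 2-carboxyethyl chain, on the saturated chain carbon bound to an aromatic carbon and a saturated chain carbon, gives a 1.8-fold lower number from compound 3 to compound 4 (0.26 log units; within the scatter) and replacing the 2-carboxycyclopropyl group gives a 1.8-fold lower number from compound 1 to compound 4 (0.26 log units; within the scatter), so the new methyl alone cannot be separated from ordinary repeat variation. Nothing available here explains why this one pair of side chains should part in tissue distribution.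

The compounds shown leave open what an ethyl group, or a second methyl, on that same chain carbon would do to this number. They also leave open whether a longer chain between the shared core and the carboxylic acid would keep the number within the scatter of these four compounds.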